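Swapping a Bicyclic Ring for a Furan on Compound 1

The source may hold more compounds than are shown below. What is called first, only, known or untested is meant among the compounds shown, and "the series" means these compounds.

Compound 1 `CCN(c1ccc(C#N)c(Cl)c1)c1cc(-n2cnc3ccccc32)ccc1C` was tested in a functional assay on CWR22R cells (Homo sapiens) for antiproliferative activity, read by CCK-8 assay, with a stated time of 6 days (on this read-out lower numbers stand for stronger inhibition and higher numbers for weaker inhibition), and gave 3040 nM. Compound 2 `Cn1nccc1-c1cccc2c1CCCN2c1ccc(C#N)c(C(F)(F)F)c1` gave 10400 nM, so compound 1 carries the lower of the two numbers, and this gap lies beyond the usual scatter of such measurements. Compound 3 `N#Cc1ccc(N2CCc3cc(-c4cncnc4)ccc3C2)cc1C(F)(F)F` belongs to the same set, but its result in this assay is given as "not determined" (no result reported), so no number was obtained for it. Compound 4 `CCN(c1ccc(C#N)c(Cl)c1)c1cc(-c2ccoc2)ccc1C` has not been measured yet. It differs from compound 1 in one place: furan-3-yl in place of 1H-benzimidazol-1-yl on an aromatic carbon. Within the data shown here, no measured pair differing in only one place shows how such a swap plays out, so the expectation rests on compound 1 alone. The step of a 1.6-fold higher number from compound 1 to compound 4 (0.22 log units; within the scatter) is expected to be small, toward a somewhat higher number, and may not exceed the scatter. Compound 4 is therefore estimated at 5000 nM, with a range from 1500 nM to 16000 nM.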

Compound 4, half-maximal inhibitory concentration: > 30000 nM
Compound 4 was reported as a limit; the forecaster's own chance of this, stated with the estimate: 10%; middle value at least 6.0-fold (0.77 log units) from the limit.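

At this aromatic carbon, para to a methyl group, furan-3-yl in place of 1H-benzimidazol-1-yl gives an at least 9.8-fold higher number from compound 1 to compound 4 (0.99 log units; beyond the scatter), so the choice of ring here clearly matters in this assay. The value for compound 4 is a limit, not a number: the limit of > 30000 nM in this assay, at which 1 of the 4 values shown sits.

With a single swap, the compounds shown leave open whether the outcome follows from losing the six-membered aromatic ring, from the change in hetero atoms, or from both. They also leave open how a phenyl ring, an amine or a carboxylic acid would fare on this carbon.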